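Adding Fluoro Ortho to Trifluoromethyl: Compound 3 Expected

The source may report more compounds than this note shows. Statements on the series, on what has been measured and on what is new or still open speak of the compounds shown alone.

Compound 1, `C[C@H](NC(=O)Nc1cccc(C(F)(F)F)c1)c1ccccc1`: 94%
Compound 2, `C[C@H](NC(=O)Nc1cccc(Br)c1)c1ccccc1`: 100%

Of the compounds shown here, two sharing one core have been measured in an ADME assay on the whole organism with Oryza sativa as the target, tested at 0.1 uM; on this read-out lower numbers stand for a stronger effect and higher numbers for a weaker effect at the one concentration tested. In this assay compound 1 gives 94%, and compound 2 gives 100%. The single step between them, bromo in place of trifluoromethyl on an aromatic carbon, is a number 6 percentage points higher from compound 1 to compound 2 (within the scatter), so compound 1 stands level with compound 2 on the numbers shown; neither can be told apart from the other.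

Compound 3, `C[C@H](NC(=O)Nc1cccc(C(F)(F)F)c1F)c1ccccc1`, is not yet measured. It differs from compound 1 by fluoro in place of hydrogen on an aromatic carbon, the new fluoro sitting ortho to a trifluoromethyl group on the six-membered aromatic ring of carbon only.

Among the compounds with values here, no measured step adds an atom to that ring; the only step known, a number 6 percentage points higher from compound 1 to compound 2 (within the scatter), exchanges one group at the same ring and stays within the scatter. With nothing pointing either way, compound 3 is expected to show a step of a number 1 percentage points higher from compound 1 to compound 3 (within the scatter), that is, none beyond the scatter. Compound 3 is therefore estimated at 95%, with a range from 82% to 100%.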

Compound 3, a percentage reported as activity, at one concentration (the size of the read-out at that concentration, not a potency): 99%
For compound 3 the middle estimate is 4 percentage points below the measured one; the range from low to high includes it.
By their numbers in this assay, from the lowest: compounds 1, 3 and 2 (each within the scatter of the next).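

In this assay, within the data shown here, the first step that adds an atom to the ring instead of exchanging a group, fluoro in place of hydrogen on an aromatic carbon, ortho to a trifluoromethyl group, gives a number 5 percentage points higher from compound 1 to compound 3 (within the scatter). This position on the six-membered aromatic ring of carbon only therefore accepts a fluoro with a read-out that cannot be told apart from that of the compound carrying hydrogen there, so neither the added fluoro nor the earlier exchange of trifluoromethyl for bromo yields a step beyond the scatter. Nothing available gives a measured property that bears on this result, so the data offer no explanation for it.

The compounds shown leave open whether a larger or differently built group at this same position, such as a methoxy group, an amine or a carboxylic acid, would produce a step beyond the scatter. They also leave open whether the fluoro would behave in the same way with bromo in place of trifluoromethyl, and whether any change to the shared core can move this read-out at the one concentration tested.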